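The compounds below may be only part of what the source reports. "The series", "measured", "known", "first", "only" and "open" are said of these compounds alone.

Measured compounds:
- compound 1, `COc1ccc(/C=C/C2CC(=O)C=CO2)cc1OC`: 146 uM
- compound 2, `COc1cc(/C=C/C2CC(=O)C=CO2)cc(OC)c1OC`: 223 uM
- compound 3, `COc1ccc(/C=C/C2CC=CC(=O)N2)cc1`: 842 uM

In a functional assay on NCI/ADR cells (Homo sapiens) for inhibition, read by sulforhodamine B assay, with a stated time of 48 h (a lower number here means a stronger inhibitor of growth, a higher number a weaker inhibitor of growth), compound 1 gives 146 uM and compound 2 gives 223 uM. The two differ by one change, (methoxy in place of hydrogen on an aromatic carbon), and the step of a 1.5-fold higher number from compound 1 to compound 2 (0.18 log units; within the scatter) is within the scatter, so the two values cannot be told apart in rank.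

Compound 3 rests on a different core, and the difference between the two cores is not broken down here. In this assay compound 3 gives 842 uM, the highest of the three numbers, beyond the scatter from both compound 1 and compound 2.

Compound 4, `COc1ccc(/C=C/C2CC=CC(=O)N2)c(OC)c1`, has not yet been measured. It differs from compound 3 by methoxy in place of hydrogen on an aromatic carbon. This is the same kind of change as from compound 1 to compound 2, but not the same: in compound 2 the methoxy enters ortho to a methoxy group and meta to the group of 9 heavy atoms, whereas in compound 4 it enters ortho to the group of 9 heavy atoms and meta to a methoxy group. Going by the values given here, only one earlier example of the change exists, on another core, so the expectation is weak.

Given that the one earlier step of a 1.5-fold higher number from compound 1 to compound 2 (0.18 log units; within the scatter) lay within the scatter, compound 4 is expected to sit close to compound 3, with an estimated step of a 1.2-fold higher number from compound 3 to compound 4 (0.07 log units; within the scatter). For compound 4 in this assay the estimate is 1000 uM, expected to fall between 400 uM and 2500 uM.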

Compound 4, concentration for growth inhibition (reported as GI): > 964 uM
Compound 4: no number, only a limit; the forecaster's own chance of this, stated with the estimate: 25%; the middle value does not contradict the limit.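

In this assay compound 4 gives > 964 uM, which is a limit of the assay and not a number. The step for methoxy in place of hydrogen on an aromatic carbon can therefore be read only as a floor, an at least 1.1-fold higher number from compound 3 to compound 4 (0.05 log units; that floor lies within the scatter), and set beside the earlier step it compares as follows: the same change on two cores in this assay, a 1.5-fold higher number (0.18 log units; within the scatter) from compound 1 to compound 2 and an at least 1.1-fold higher number (0.05 log units; that floor lies within the scatter) from compound 3 to compound 4; the limit leaves it open whether they differ. Going by these compounds, neither core gives any sign that this change lowers the number, but the data do not show that the step carries over unchanged from one core to the other, since the true size of the step on the core of compound 3 stays unknown, with the reading stopped at the limit: the limit of > 964 uM in this assay, at which 1 of the 4 values shown sits.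

The methoxy also enters at a different place in compound 2 and in compound 4, so with only these two steps the effect of place cannot be separated from that of the core. Still open, on these data alone, is how either core would respond to a group other than methoxy on the aromatic ring, such as an amine or a carboxylic acid, and whether any such group would bring the number on the core of compound 3 down from the range seen so far.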